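The source may report more compounds than this note shows. Statements on the series, on what has been measured and on what is new or still open speak of the compounds shown alone.

Working notes on the series, read in a functional assay on MDA-MB-231 cells (Homo sapiens) for inhibition, read by MTT assay, with a stated time of 48 h; a higher number here means a weaker inhibitor, a lower number a stronger inhibitor.

Compound 3 (`CCn1c(/C=C2\SC(=O)N(CC(=O)N3CCCC3)C2=O)nc2ccccc21`) is the starting point for this step. Compound 3 gives > 50000 nM, which is a limit and not a number. Compound 1 (`CCn1c(/C=C2\SC(=O)N(CC(=O)N3CCCCC3)C2=O)nc2ccccc21`) gives > 50000 nM, also a limit. Compound 2 (`CCn1c(/C=C2\SC(=O)N(CC(=O)Nc3cc(C(C)(C)C)on3)C2=O)nc2ccccc21`) gives > 50000 nM, again a limit. Across these three compounds, the picture is the limit of > 50000 nM in this assay, at which 3 of the 3 values shown sit.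

Compound 4 (`CCn1c(/C=C2\SC(=O)N(CC(=O)N3CC(C)OC(C)C3)C2=O)nc2ccccc21`) keeps the shared core and carries 2,6-dimethylmorpholin-4-yl in place of pyrrolidin-1-yl on a carbonyl carbon.

Three measured steps change this same group: a step that the two limits leave unreadable from compound 1 to compound 3, a step that the two limits leave unreadable from compound 1 to compound 2 and a step that the two limits leave unreadable from compound 2 to compound 3. None of them has a readable size, so they offer no measured effect to carry over to the new group, and they point in no direction. Within the data shown here, the closest comparison is the swap between the two saturated rings in compound 1 and compound 3, and it shows only that both compounds stay at the limit.

The expectation is therefore no step beyond the scatter, with compound 4 most likely reported at the same limit. The expected step is a number no higher from compound 3 to compound 4 (the limit leaves the size open), an estimate without a supported direction. For compound 4 the estimated value is 50000 nM, with an expected range from 20000 nM to 100000 nM.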

Compound 4, half-maximal inhibitory concentration: > 50000 nM
Compound 4 was reported as a limit (the forecaster's own chance of this, stated with the estimate: 80%); the middle value sits exactly at the limit.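

In this assay compound 4 gives > 50000 nM, which is a limit. The steps to compound 4 from compound 1, compound 2 and compound 3 cannot be read, and the series shows a single picture: the limit of > 50000 nM in this assay, at which 4 of the 4 values shown sit.

The compounds shown leave open how far each lies past the limit and whether any group on the carbonyl carbon gives a measurable value.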